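The compounds below may be only part of what the source reports. "The series", "measured", "known", "first", "only" and "open" are said of these compounds alone.

Measured in an ADME assay on HepG2 2.2.15 cells (Homo sapiens) for cytotoxicity, read by MTT assay, with stated times of 48 h and 9 days; on this read-out lower numbers stand for higher toxicity in this test and higher numbers for lower toxicity in this test:
compound 1 `COc1ccc2c(=O)c(/C=C/C(=O)Nc3cccc(C)c3)coc2c1` — 554000 nM
compound 2 `COc1ccc2c(=O)c(/C=C/C(=O)Nc3ccccc3Cl)coc2c1` — 1010000 nM

Compound 1 stands at 554000 nM, and compound 2 at 1010000 nM sits within the scatter of it; the step is a 1.8-fold higher number from compound 1 to compound 2 (0.26 log units; within the scatter). Compound 3 `COc1ccc2c(=O)c(/C=C/C(=O)NCc3ccc(F)cc3F)coc2c1` is not yet measured. It differs from compound 1 by 2,4-difluorobenzyl in place of 3-methylphenyl on an amide-type nitrogen. For the measured compounds named here, the only step known, from compound 1 to compound 2, also swaps the group on the amide-type nitrogen and stays within the scatter, so no step beyond the scatter is expected in this assay: a 1.1-fold higher number from compound 1 to compound 3 (0.03 log units; within the scatter). Compound 3 is therefore expected to give 600000 nM, within a range of 250000 nM to 1500000 nM.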

Compound 3, half-maximal cytotoxic concentration: 79300 nM
The estimate for compound 3 lay 7.6-fold (0.88 log units) above the measured number; measured number outside the range, below it.
By their numbers in this assay, from the lowest: compound 3; then compounds 1 and 2 (each within the scatter of the next).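

Within this assay the group on the amide-type nitrogen does move the number: 2,4-difluorobenzyl reads as higher toxicity in this test than 3-methylphenyl (a 7.0-fold lower number from compound 1 to compound 3 (0.84 log units; beyond the scatter)) and than 2-chlorophenyl (a 13-fold lower number from compound 2 to compound 3 (1.11 log units; beyond the scatter)). The swap between those two earlier groups stayed within the scatter, so this position is not indifferent to every exchange. Nothing available bears on the reason for the shift.

Compound 3 brings in the benzyl form and the two fluorines together, and the compounds shown do not separate them. On these data alone, whether plain benzyl or a longer chain such as phenethyl would read like compound 3 or like compound 1 remains open.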